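Swapping a phenyl for a butyl on the triazole

The source may hold more compounds than are shown below. What is called first, only, known or untested is meant among the compounds shown, and "the series" means these compounds.

Measured compounds:
compound 1 `COc1nc2ccc(Br)cc2cc1C(c1ccccc1)n1cc(-c2ccc(Br)cc2)nn1` — 13.4%
compound 2 `COc1nc2ccc(Br)cc2cc1C(c1ccccc1)n1cc(-c2ccccc2)nn1` — 13.7%

In an ADME assay on SK-OV-3 cells (Homo sapiens) for cytotoxicity, read by sulforhodamine B assay, with a stated time of 48 h, tested at 10 uM (on this read-out lower numbers stand for less inhibition and higher numbers for more inhibition at the one concentration tested (going by the name of the read-out)), compound 2 gives 13.7% and compound 1 gives 13.4%; compound 2 stands highest of the two numbers, but only by a number 0.3 percentage points higher from compound 1 to compound 2 (within the scatter), so the two are indistinguishable. Compound 3 `CCCCc1cn(C(c2ccccc2)c2cc3cc(Br)ccc3nc2OC)nn1` differs from compound 2 by butyl in place of phenyl on an aromatic carbon. Among the compounds with values here, the only measured step, a number 0.3 percentage points higher from compound 1 to compound 2 (within the scatter), changed a bromo on the triazole substituent and did not move the read-out; it does not directly cover replacing the whole phenyl, so the expectation is loose. For compound 3 the estimated step is a number 0.7 percentage points lower from compound 2 to compound 3 (within the scatter), no change beyond the scatter. Compound 3 is expected to give 13%, between 3% and 25%.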

Compound 3, a percentage reported as inhibition, at one concentration (the size of the read-out at that concentration, not a potency): 11.1%
Estimate against measurement, compound 3: 1.9 percentage points above; low and high end bracket the measured number.
By their numbers in this assay, from the lowest: compounds 3, 1 and 2 (each within the scatter of the next).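

Until now only a bromo on the phenyl had changed; here the whole aromatic ring at this position gives way to an open chain. In this assay that swap gives a number 2.6 percentage points lower from compound 2 to compound 3 (within the scatter) and, set against the 4-bromophenyl, a number 2.3 percentage points lower from compound 1 to compound 3 (within the scatter) so among these compounds butyl stands in for either aromatic group with no change beyond the scatter. Going by these compounds, whether an amine, a carboxylic acid or a longer chain on this carbon would shift the number remains open. Nothing available here bears on why these values stay so close.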